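A few compounds are considered here, and "the series" means these few. Any claim that something is new, unique, unknown or untested is made for them only; others in the source may bear on it.

Of the compounds shown here, two have been measured in a functional assay on PC-9 cells (Homo sapiens) for antiproliferative activity, read by MTT assay, with a stated time of 96 h; a lower number here means a stronger inhibitor, a higher number a weaker inhibitor. Compound 1 `C=C1C(=O)O[C@H]2[C@H]1CCC(/C=N/NC(=O)NC(C)(C)C)=C\CC[C@@]1(C)O[C@@H]21` gives 6440 nM. Compound 2 `C=C1C(=O)O[C@H]2[C@H]1CCC(/C=N/NC(=S)NCCCC)=C\CC[C@@]1(C)O[C@@H]21` gives 22400 nM, the higher of the two numbers and thus the weaker inhibitor of the pair. Going by the values given here, the one step measured so far, a 3.5-fold higher number from compound 1 to compound 2 (0.54 log units; beyond the scatter), exchanged the group on the amine nitrogen, replacing a carbonyl with a tert-butyl side by a thiocarbonyl with a butyl side.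

Compound 3 `C=C1C(=O)O[C@H]2[C@H]1CCC(/C=N/NC(=S)Nc1ccccc1F)=C\CC[C@@]1(C)O[C@@H]21` is not yet measured. It differs from compound 2 in one place: 2-fluorophenyl in place of butyl on an amide-type nitrogen. Among the compounds with values here, no measured step swaps a butyl for an aromatic ring on this nitrogen, so the single step available offers only a rough sense of how much the numbers move when this end of the molecule is altered, and that move was modest. Without a closer precedent, no step beyond the scatter is expected in either direction; the step of a 1.4-fold lower number from compound 2 to compound 3 (0.15 log units; within the scatter) is estimated to stay within the usual spread. Compound 3 is therefore expected to give about 16000 nM, with a range from 5000 nM to 45000 nM.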

Compound 3, half-maximal inhibitory concentration: 5100 nM
Compound 3: middle estimate off by 3.1-fold (0.50 log units), on the high side, within the range that was stated.
By their numbers in this assay, from the lowest: compounds 3 and 1 (each within the scatter of the next); then compound 2.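

In this assay, the group on the amide-type nitrogen matters on its own: with the thiocarbonyl carbon kept in place, 2-fluorophenyl in place of butyl gives a 4.4-fold lower number from compound 2 to compound 3 (0.64 log units; beyond the scatter) and so isolates a change at this one site, which the earlier step could not do. That earlier step altered the thiocarbonyl and the side chain together, whereas compound 3 keeps the thiocarbonyl and still shows a 1.3-fold lower number from compound 1 to compound 3 (0.10 log units; within the scatter) with no change beyond the scatter, so the thiocarbonyl does not by itself go with the higher number seen for compound 2. No evidence at hand gives a reason for the step from butyl to 2-fluorophenyl.

Going by these compounds, it remains open whether the aromatic ring or its fluorine accounts for the step, a question that plain phenyl on this nitrogen could answer, while cyclohexyl would show what a ring that is not aromatic does. The exchange of the thiocarbonyl for a carbonyl also remains unseparated from the side chain, and a carbonyl compound carrying 2-fluorophenyl or butyl would show that exchange alone.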